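The source may report more compounds than this note shows. Statements on the series, on what has been measured and on what is new or still open speak of the compounds shown alone.

The series shares one core: an amide linking a pyridazinone-bearing aryl to an aryl ether carrying a fused thienopyrimidine. Compound 1 `Cc1cc(=O)n(-c2ccccc2C(F)(F)F)nc1C(=O)Nc1ccc(Oc2ncnc3sccc23)cc1` returns only a limit in a functional assay on HepG2 cells (Homo sapiens) for cytotoxicity, read by MTT assay, with a stated time of 72 h (a higher number here means a weaker inhibitor, a lower number a stronger inhibitor), namely > 40000 nM, which is a limit of the assay rather than a number (the limit of > 40000 nM in this assay, at which 1 of the 3 values shown sits). Compound 2 `Cc1cc(=O)n(-c2cccc(F)c2)nc1C(=O)Nc1ccc(Oc2ncnc3sccc23)c(F)c1` gives 24500 nM in this assay. Compound 3 `O=C(Nc1ccc(Oc2ncnc3ccsc23)c(F)c1)c1nn(-c2ccc(F)cc2)ccc1=O` gives 9160 nM in this assay, the lowest of the two numbers in hand and lower than compound 2 by a gap that lies beyond the usual scatter.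

Compound 4 `O=C(Nc1ccc(Oc2ncnc3ccsc23)c(F)c1)c1nn(-c2ccc(Br)cc2)ccc1=O` differs from compound 3 in one place: bromo in place of fluoro on an aromatic carbon, so that the 4-fluorophenyl on the pyridazinone nitrogen becomes a 4-bromophenyl. Going by the values given here, no measured pair isolates this exchange, so nothing in the data shows its size or direction. The three measured compounds all sit at weak potency, and the halogen exchange is expected to move compound 4 little in this assay, with a step from compound 3 of a 1.2-fold lower number from compound 3 to compound 4 (0.09 log units; within the scatter) expected to stay within the scatter. Compound 4 is therefore estimated at 7500 nM in this assay, within a range of 2500 nM to 22000 nM.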

Compound 4, half-maximal inhibitory concentration: 10700 nM
The estimate for compound 4 lay 1.4-fold (0.15 log units) below the measured number; measured number inside the range.
By their numbers in this assay, from the lowest: compounds 3 and 4 (each within the scatter of the next); then compound 2. At a limit, above all of these: compound 1.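

Going by these compounds alone, the exchange of 4-fluorophenyl to 4-bromophenyl provides the first pair that differs in one place, and in this assay it gives a 1.2-fold higher number from compound 3 to compound 4 (0.07 log units; within the scatter) between two otherwise identical structures. Within the data shown here, at this position, on an aromatic carbon of the ring on the pyridazinone nitrogen and para to a large group, the swap of one halogen for another therefore leaves the number unchanged within the scatter, something the earlier compounds, which differ in several places at once, could not show. No measurement shown here bears on why the number holds across this exchange.

Going by these compounds, whether a group of another kind at this place, such as an amine, a carboxylic acid, a methoxy group or a longer alkyl chain, would move the number beyond the scatter remains open, as does the result for a phenyl ring with no substituent at all. On these data alone, the finding also rests on this single pair, so it remains open whether the same exchange would behave alike on the methyl-bearing compounds with the other fused ring orientation, such as compound 2.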